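The source may report more compounds than this note shows. Statements on the series, on what has been measured and on what is new or still open speak of the compounds shown alone.

Compound 1, `Cc1ccc(-c2ccc(NC3=CC(=O)c4ncncc4C3=O)cc2F)cc1`, gives 5000 nM in a functional assay on BXPC-3 cells (Homo sapiens) for cytotoxicity, read by MTT assay, with a stated time of 72 h; a higher number here means a weaker inhibitor, a lower number a stronger inhibitor. Compound 2, `COC(=O)c1ccc(NC2=CC(=O)c3ncncc3C2=O)cc1`, gives 5800 nM in this assay. Compound 3, `CC(=O)c1cccc(NC2=CC(=O)c3ncncc3C2=O)c1`, gives 5200 nM in this assay.

All three compounds share the same core and differ only in the aromatic ring attached through the amine nitrogen. On the numbers shown, compound 2 carries the highest of the three, but its gap to compound 3 and its gap to compound 1 both lie within the usual scatter of repeated measurements, so the three compounds cannot be told apart in this assay.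

Compound 4, `NC(=O)c1ccc(NC2=CC(=O)c3ncncc3C2=O)cc1`, has not yet been measured. It differs from compound 2 by a single change: amino in place of methoxy on a carbonyl carbon. For the measured compounds named here, no pair of measured compounds shows what this kind of change does here, so there is no measured step to lean on. Given how little the three measured compounds differ from one another, the expected step in this assay from compound 2 to compound 4 is none beyond the scatter, in either direction. For compound 4 the estimated value is 5500 nM, with a range from 2500 nM to 12000 nM, and the estimated step of a 1.1-fold lower number from compound 2 to compound 4 (0.02 log units; within the scatter) is therefore expected to be small.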

Compound 4, half-maximal inhibitory concentration: > 10000 nM
Compound 4 ended at the assay's limit (the forecaster's own chance of this, stated with the estimate: 10%); middle value at least 1.8-fold (0.25 log units) away from the limit.
By their numbers in this assay, from the lowest: compounds 1, 3 and 2 (each within the scatter of the next). At a limit, above all of these: compound 4.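

In this assay, compound 4 gives > 10000 nM, which is a limit of the assay and not a number. For the compounds shown here, this is the first step at this place on the molecule: amino in place of methoxy on a carbonyl carbon gives an at least 1.7-fold higher number from compound 2 to compound 4 (0.23 log units; that floor lies within the scatter), so the reading leans towards a weaker compound, but it does not establish a real loss. The true size of the step stays unknown, since the reading stops at the limit: the limit of > 10000 nM in this assay, at which 1 of the 4 values shown sits.

From the compounds shown here alone, it remains open whether a carboxylic acid, a methylamide or an ethyl ester in place of the methoxycarbonyl group would give a value that can be read within the assay's range. Going by these compounds, it is also open whether the change from methoxycarbonyl to carbamoyl would read the same at another place on the ring.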